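The compounds below may be only part of what the source reports. "The series", "measured", "known", "first", "only" and "open" are said of these compounds alone.

Measured so far in an ADME assay on J774 cells (Mus musculus, strain BALB/c) for cytotoxicity, read by resazurin assay, with a stated time of 72 h; on this read-out lower numbers stand for higher toxicity in this test and higher numbers for lower toxicity in this test:
compound 1 `CC(/C=N/N(C)c1ccc([N+](=O)[O-])cc1)=N\NC(=O)c1cc([N+](=O)[O-])cc([N+](=O)[O-])c1` — compound 1 gives 39000 nM.
compound 2 `COc1cc(C(=O)N/N=C(C)/C=N/Nc2ccc([N+](=O)[O-])cc2)ccc1O` — compound 2 reaches only the limit of the assay, > 100000 nM.
compound 3 `CC(/C=N/Nc1ccc([N+](=O)[O-])cc1)=N\NC(=O)c1ccccc1Oc1ccccc1` — compound 3 likewise reaches only the limit of the assay, > 100000 nM.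

Compound 2 thus stands at the limit of this assay, not at a number, and compound 3 sits at the same limit; the point is recorded as the limit of > 100000 nM in this assay, at which 2 of the 3 values shown sit. Only compound 1 yields a measured value, and it lies a good way inside the range of the assay. Going by the values given here, no pair among the three shares a single structural change, so no measured step is available to guide the next compound.

Compound 4 `CC(/C=N/Nc1ccc([N+](=O)[O-])cc1)=N\NC(=O)c1ccc(N)cc1` differs from compound 2 in one place: 4-aminophenyl in place of 4-hydroxy-3-methoxyphenyl on a carbonyl carbon. Since compound 2 is known only as a limit, the shown compounds give no direction for this change. The step from compound 2 to compound 4 is expected to be none beyond the scatter, with the most likely outcome that this assay again reports only its limit, as the expected step of a number no higher from compound 2 to compound 4 (the limit leaves the size open) shows. For compound 4 the estimated value in this assay is 100000 nM, with a range from 40000 nM to 150000 nM.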

Compound 4, half-maximal cytotoxic concentration: 75000 nM
For compound 4 the middle estimate is 1.3-fold (0.12 log units) above the measured one; measured number inside the range.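

With 4-aminophenyl in place of 4-hydroxy-3-methoxyphenyl on a carbonyl carbon, this assay returns a number at this position rather than a limit: compound 4 gives 75000 nM. The change amounts to an at least 1.3-fold lower number from compound 2 to compound 4 (0.12 log units; that floor lies within the scatter), so the position can carry a group that brings the read-out inside the range of the assay, yet the floor alone does not show a change beyond the scatter. The true size of the step stays unknown because compound 2 is known only as a limit: the limit of > 100000 nM in this assay, at which 2 of the 4 values shown sit.

The compounds shown leave open how large this step really is, and whether it comes from the amine itself, from the loss of the hydroxy and methoxy groups, or from both, since the single swap changes all of these at once. Also open, on these data alone, is how this assay would read with a 4-carboxyphenyl group or a 4-(dimethylamino)phenyl group on the same carbonyl carbon, or with a phenyl group carrying only the hydroxy or only the methoxy of compound 2.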